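The source may hold more compounds than are shown below. What is called first, only, known or untested is meant among the compounds shown, and "the series" means these compounds.

Compound 1 `CN1C/C(=C\c2ccc(F)cc2)C(=O)/C(=C/c2cccc([N+](=O)[O-])c2)C1`: 9340 nM
Compound 2 `CN1C/C(=C\c2ccc(Cl)cc2)C(=O)/C(=C/c2cccc([N+](=O)[O-])c2)C1`: 8210 nM

For the measured compounds named here, in a functional assay on HepG2 cells (Homo sapiens) for cytotoxicity, read by MTT assay, with a stated time of 24 h (on this read-out higher numbers stand for weaker inhibition and lower numbers for stronger inhibition), compound 2 gives 8210 nM, a number within the usual scatter of the one for compound 1, so the two cannot be told apart.

Compound 3 `CN1C/C(=C\c2ccc(Br)cc2)C(=O)/C(=C/c2cccc([N+](=O)[O-])c2)C1` has not yet been measured. It differs from compound 2 in a single place: bromo in place of chloro on an aromatic carbon. In words, this is bromo in place of chloro on an aromatic carbon, para to a large group.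

Going by the values given here, only one measured step bears on this change, and it is the same kind of swap: a 1.1-fold lower number from compound 1 to compound 2 (0.06 log units; within the scatter), with chloro in place of fluoro on an aromatic carbon. A single step is thin evidence, but it gives no reason to expect a real shift in this assay. The expected change is a 1.1-fold lower number from compound 2 to compound 3 (0.04 log units; within the scatter), which would not go beyond the scatter. For compound 3 the estimated value is 7500 nM, with an expected range from 3800 nM to 14000 nM.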

Compound 3, half-maximal inhibitory concentration: 8800 nM
Compound 3: the middle estimate sits 1.2-fold (0.07 log units) below what was measured; measured number inside the range.
By their numbers in this assay, from the lowest: compounds 2, 3 and 1 (each within the scatter of the next).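

In this assay the swap from chloro to bromo gives a 1.1-fold higher number from compound 2 to compound 3 (0.03 log units; within the scatter) and the swap from fluoro to bromo gives a 1.1-fold lower number from compound 1 to compound 3 (0.03 log units; within the scatter) and so fluoro, chloro and bromo at this place cannot be told apart. Earlier a single pair spoke for this position, whereas now every pair among the three compounds stays within the scatter, so exchanging one of these halogens for another on this aromatic carbon shows no measurable effect here. No measured property is available to account for this flat result.

Going by these compounds, all three compounds carry a halogen at this place, so it remains open whether a group of another kind, such as an amine, a carboxylic acid or a methoxy group, would move the number beyond the scatter. The rest of the shared core stays the same throughout, so what a change there would do is also unknown.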